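This account rests on a few compounds, and the source may have more. Where it says the series, first, only, none or still open, it means among the compounds named here.

In a functional assay on MDA-MB-468 cells (Homo sapiens) for antiproliferative activity, read by MTT assay, with a stated time of 48 h; on this read-out higher numbers stand for weaker inhibition and lower numbers for stronger inhibition:
- compound 1 `CN(C)CCNc1cc2c(cn1)cc(NC(=O)c1ccc(N)cc1)c(=O)n2C`: 20400 nM
- compound 2 `CN(C)CCNc1cc2c(cn1)cc(NC(=O)c1cc3ccccc3s1)c(=O)n2C`: 3570 nM
- compound 3 `COc1cccc(C(=O)Nc2cc3cnc(NCCN(C)C)cc3n(C)c2=O)c1`: 17400 nM

These compounds share a core and differ only in the group on the amide carbonyl. In this assay, compound 3 gives 17400 nM. It cannot be told apart from compound 1, since the measured change is a 1.2-fold lower number from compound 1 to compound 3 (0.07 log units; within the scatter). It is clearly weaker than compound 2, with a 4.9-fold higher number from compound 2 to compound 3 (0.69 log units; beyond the scatter).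

The next compound, compound 4 `CN(C)CCNc1cc2c(cn1)cc(NC(=O)/C=C/c1ccccc1)c(=O)n2C`, changes the same group: 2-phenylethenyl in place of 3-methoxyphenyl on a carbonyl carbon. The entering group keeps a six-membered aromatic ring of carbon only and adds a double bond outside aromatic rings.

Within the data shown here, no measured compound carries this group, so the guide is what swaps at this place have done so far. Replacing one substituted phenyl with another gave a 1.2-fold lower number from compound 1 to compound 3 (0.07 log units; within the scatter), while the one clear shift came with 1-benzothiophen-2-yl, a 5.7-fold lower number from compound 1 to compound 2 (0.76 log units; beyond the scatter). A step within the scatter, or a modest one toward a lower number, therefore seems most likely. The expected change is a 1.7-fold lower number from compound 3 to compound 4 (0.24 log units; within the scatter). The estimate for compound 4 is 10000 nM, with an expected range of 3500 nM to 25000 nM.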

Compound 4, half-maximal inhibitory concentration: 12100 nM
The estimate for compound 4 lay 1.2-fold (0.08 log units) below the measured number; low and high end bracket the measured number.
By their numbers in this assay, from the lowest: compound 2; then compounds 4, 3 and 1 (each within the scatter of the next).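

Swapping 3-methoxyphenyl for 2-phenylethenyl on the carbonyl carbon removes a hydrogen-bond acceptor and adds a double bond outside aromatic rings, yet this assay shows a 1.4-fold lower number from compound 3 to compound 4 (0.16 log units; within the scatter) and, against 4-aminophenyl, a 1.7-fold lower number from compound 1 to compound 4 (0.23 log units; within the scatter), so neither comparison separates the groups. Compound 2 still stands apart from this new group, with a 3.4-fold higher number from compound 2 to compound 4 (0.53 log units; beyond the scatter), which leaves 1-benzothiophen-2-yl as the only group shown here whose number differs clearly from the others, though with a modest step and not a large one. None of the available data explains why this group stands apart or why the other three do not differ.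

From the compounds shown here alone, it remains open whether the double bond matters at all, and 2-phenylethyl, the same group with a saturated chain, would test that directly against compound 4. Going by these compounds, it is also open whether the sulfur or the fused ring system goes with the lower number of compound 2, a question that 1-benzofuran-2-yl, with oxygen in place of sulfur, and 2-naphthyl, with carbon only, could help to settle.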